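Pyridinylmethyl amine replaces diisopentylamine on a sulfamate

This account rests on a few compounds, and the source may have more. Where it says the series, first, only, none or still open, it means among the compounds named here.

Compound 1 `CCN(Cc1cccnc1)c1ccc(C(=O)N2CCc3ccc(OS(N)(=O)=O)cc3C2)cc1` gives 85.2% in an assay on HEK293 cells for inhibition of Steryl-sulfatase (Homo sapiens), tested at 1 uM; a lower number here means a weaker effect, a higher number a stronger effect of the compound at the concentration tested. Compound 2 `CC(C)CCN(CCC(C)C)c1ccc(C(=O)N2CCc3ccc(OS(N)(=O)=O)cc3C2)cc1` gives 90.8%. Compound 3 `CCN(Cc1ccncc1)c1cccc(C(=O)N2CCc3ccc(OS(N)(=O)=O)cc3C2)c1` gives 52.8%.

Compound 2 holds the highest of the three numbers; compound 1 lies within the scatter of it, while compound 3 lies beyond the scatter below it. Compound 4 `CCN(Cc1ccncc1)c1ccc(C(=O)N2CCc3ccc(OS(N)(=O)=O)cc3C2)cc1` is not yet measured. It differs from compound 2 as follows: ethyl((pyridin-4-yl)methyl)amino in place of diisopentylamino on an aromatic carbon. Within the data shown here, the only step that bears on this is a number 5.6 percentage points higher from compound 1 to compound 2 (within the scatter), a change between the same two kinds of group, which stayed within the scatter. Compound 3 carries the entering group but joined to the core differently, so its value is only a loose pointer. For compound 4 a step of about a number 7.8 percentage points lower from compound 2 to compound 4 (within the scatter) is therefore expected, none beyond the scatter. Compound 4 is estimated at 83%, between 70% and 93%.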

Compound 4, a percentage reported as inhibition, at one concentration (the size of the read-out at that concentration, not a potency): 86.6%
Beside the measured number, compound 4's estimate is 3.6 percentage points below it; low and high end bracket the measured number.
By their numbers in this assay, from the lowest: compound 3; then compounds 1, 4 and 2 (each within the scatter of the next).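

In this assay, pyridin-4-yl in place of pyridin-3-yl on the saturated chain carbon gives a number 1.4 percentage points higher from compound 1 to compound 4 (within the scatter) and so leaves the two pyridine isomers unseparated at this concentration. Ethyl((pyridin-4-yl)methyl)amino in place of diisopentylamino gives a number 4.2 percentage points lower from compound 2 to compound 4 (within the scatter) and so joins a number 5.6 percentage points higher from compound 1 to compound 2 (within the scatter) as a second swap of this kind that stays within the scatter, whichever pyridine isomer is involved.

Going by these compounds, how a carboxylic acid or a morpholine would fare on this aromatic carbon remains open. Single-concentration read-outs do not rank these compounds by potency, and no measurement available here explains why these groups read alike.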